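A Smaller Ring on the Amide Carbonyl

This account rests on a few compounds, and the source may have more. Where it says the series, first, only, none or still open, it means among the compounds named here.

Compound 1 `C[C@@H](NCc1ccc(Cl)cc1)[C@H]1CC[C@@H](c2ccnc3ccc(F)cc32)CC1` gives 2%
Compound 2 `C[C@@H](NC(=O)C12CCC(Cl)(CC1)CC2)[C@H]1CC[C@@H](c2ccnc3ccc(F)cc32)CC1` gives 10%

Both compounds were measured in an ADME assay on microsomes from liver (Mus musculus) for metabolic stability, with a stated time of 10 min, tested at 0.5 uM; on this read-out lower numbers stand for a less stable compound and higher numbers for a more stable compound. Compound 2, at 10%, lies within the usual scatter of compound 1 and remains near the unstable end of the scale. Compound 3 `C[C@@H](NC(=O)C1CCCCC1)[C@H]1CC[C@@H](c2ccnc3ccc(F)cc32)CC1` differs from compound 2 at one place, on a carbonyl carbon: a group of 6 heavy atoms (6 carbon; one six-membered non-aromatic ring of carbon only) in place of a group of 9 heavy atoms (8 carbon, 1 chlorine; 2 six-membered non-aromatic rings of carbon only), on a carbonyl carbon. Within the data shown here, no measured pair shows what this exchange does in this assay, so no step beyond the scatter is expected in either direction. The estimated change, a number 2 percentage points lower from compound 2 to compound 3 (within the scatter), is expected to stay within the scatter. For compound 3 the estimated value is 8%, with an expected range from 1% to 25%.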

Compound 3, percent of the compound remaining: 5%
Estimate against measurement, compound 3: 3 percentage points above; the range from low to high includes it.
By their numbers in this assay, from the lowest: compounds 1, 3 and 2 (each within the scatter of the next).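

In this assay, cyclohexyl in place of the group of 9 heavy atoms on the carbonyl carbon gives a number 5 percentage points lower from compound 2 to compound 3 (within the scatter), so taking away the chlorine and one ring has no readable effect at this position. Cyclohexylcarbonyl in place of 4-chlorobenzyl on the amine nitrogen likewise gives a number 3 percentage points higher from compound 1 to compound 3 (within the scatter), and all three compounds stay near the unstable end of the scale. No evidence on the cause of these results is at hand.

On these data alone, whether the shared core, rather than the group on this carbonyl carbon, sets these low numbers remains open. As far as these compounds go, it also remains open whether cyclopropyl or a ring carrying an amine or a carboxylic acid at this place would move the read-out beyond the scatter.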